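Removing the terminal phosphate from a uracil-nucleotide diphosphate

A few compounds are considered here, and "the series" means these few. Any claim that something is new, unique, unknown or untested is made for them only; others in the source may bear on it.

Compound 1 `CCCSc1nc(=O)ccn1[C@@H]1O[C@H](COP(=O)(O)OP(=O)(O)O)[C@@H](O)[C@H]1O`: >= 100000 nM
Compound 2 `CNc1nc(=O)ccn1[C@@H]1O[C@H](COP(=O)(O)OP(=O)(O)O)[C@@H](O)[C@H]1O`: > 100000 nM

In an in vitro functional assay on 1321-N1 cells for agonist activity at P2Y purinoceptor 6 (Homo sapiens), read by scintillation proximity assay and inositol phosphate accumulation (on this read-out lower numbers stand for an effect already at smaller amounts and higher numbers for an effect only at larger amounts of compound), compound 1 gives >= 100000 nM, a limit of the assay and not a number. Compound 2 likewise gives > 100000 nM, again a limit. Going by the values given here, the only measured step, a step that the two limits leave unreadable from compound 1 to compound 2, is therefore unreadable, as the limit of > 100000 nM in this assay, at which 1 of the 2 values shown sits, and the limit of >= 100000 nM in this assay, at which 1 of the 2 values shown sits, show. Compound 3 `CCCSc1nc(=O)ccn1[C@@H]1O[C@H](COP(=O)(O)O)[C@@H](O)[C@H]1O` differs from compound 1 by a hydrogen atom in place of a group of 4 heavy atoms (3 oxygen, 1 phosphorus; no ring), on an oxygen. Among the compounds with values here, no measured step bears on this change, so nothing supports an expectation of movement beyond the scatter. Compound 3 is expected to give 100000 nM (range 30000 nM to 300000 nM), most likely again as a limit. This estimate means a step of a number no higher from compound 1 to compound 3 (the limit leaves the size open).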

Compound 3, half-maximal effective concentration: 6200 nM
The estimate for compound 3 lay 16-fold (1.21 log units) above the measured number; the whole stated range lies above it.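

In this assay, a hydrogen atom in place of the group of 4 heavy atoms on this oxygen gives an at least 16-fold lower number from compound 1 to compound 3 (1.20 log units; beyond the scatter). This change therefore yields the first number among the compounds shown, where the earlier pair offered only limits. The full size of the step stays open, since compound 1 stands at a limit: the limit of >= 100000 nM in this assay, at which 1 of the 3 values shown sits.

As far as these compounds go, whether the same change would also move compound 2, which carries methylamino in place of propylsulfanyl, remains open. So does the effect of a longer chain or a carboxylic acid in place of propylsulfanyl on the core of compound 3.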